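This account rests on a few compounds, and the source may have more. Where it says the series, first, only, none or still open, it means among the compounds named here.

Compound 2 `Cc1nn(-c2ccccc2)cc1/C=N/Nc1nc(Nc2ccccc2)nc(Nc2ccc(S(N)(=O)=O)cc2)n1` was tested in a functional assay on U-251 cells (Homo sapiens) for inhibition, read by sulforhodamine B assay, with a stated time of 48 h (on this read-out lower numbers stand for stronger inhibition of growth and higher numbers for weaker inhibition of growth), where compound 2 gives 3650 nM. For the measured compounds named here, of the two numbers available in this assay, that of compound 2 is the higher one; its only neighbour is compound 1 `NS(=O)(=O)c1ccc(Nc2nc(N/N=C/c3ccc(C(F)(F)F)cc3)nc(Nc3ccccc3)n2)cc1`, which in this assay gives 2690 nM, and the step of a 1.4-fold higher number from compound 1 to compound 2 (0.13 log units; within the scatter) lies within the scatter, so the two compounds cannot be told apart on these numbers. The change that leads onward to compound 3 `NS(=O)(=O)c1ccc(Nc2nc(N/N=C/c3ccccn3)nc(Nc3ccccc3)n2)cc1` is pyridin-2-yl in place of 3-methyl-1-phenyl-1H-pyrazol-4-yl on a carbon with a double bond to nitrogen. Going by the values given here, only one measured step bears on this change: the earlier exchange of one aromatic group for another on the same carbon with a double bond to nitrogen, which did not move the number beyond the scatter. On that basis a third aromatic group at the same carbon is expected to leave this assay much where it was, and the expected step of a 1.2-fold lower number from compound 2 to compound 3 (0.09 log units; within the scatter) is one of no consequence beyond the scatter. Compound 3 is therefore estimated at 3000 nM in this assay, with an expected range from 1200 nM to 8000 nM.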

Compound 3, concentration for 50% growth inhibition: 510 nM
For compound 3 the middle estimate is 5.9-fold (0.77 log units) above the measured one; measured number outside the range, below it.
By their numbers in this assay, from the lowest: compound 3; then compounds 1 and 2 (each within the scatter of the next).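

In this assay, the position on the carbon with a double bond to nitrogen proves sensitive to the group it carries, which the earlier pair, lying within the scatter of each other, gave no sign of. Putting pyridin-2-yl in place of 3-methyl-1-phenyl-1H-pyrazol-4-yl brings a 7.2-fold lower number from compound 2 to compound 3 (0.85 log units; beyond the scatter), and putting it in place of 4-(trifluoromethyl)phenyl brings a 5.3-fold lower number from compound 1 to compound 3 (0.72 log units; beyond the scatter), so compound 3 stands apart from both, while the entering group has one aromatic ring with a hetero atom where the pyrazolyl group it replaces has two rings. Nothing available explains why this exchange lowers the number.

What the three compounds leave open is whether the lower number goes with the ring nitrogen of pyridin-2-yl or with the plain single ring, a question that an unsubstituted phenyl, pyridin-3-yl or pyridin-4-yl on this carbon would help to settle. Also open, going by these compounds, is whether a pyridin-2-yl group carrying a methyl or an amine would keep the number of compound 3.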